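A few compounds are considered here, and "the series" means these few. Any claim that something is new, unique, unknown or untested is made for them only; others in the source may bear on it.

Measured in a functional assay on HeLa cells (Homo sapiens) for inhibition, read by CCK-8 assay, with a stated time of 48 h (on this read-out lower numbers stand for stronger inhibition and higher numbers for weaker inhibition), so far:
compound 1 `COc1cc(-c2ccnc3cc(-c4ccc(C)c(C)c4)nn23)cc(OC)c1OC` gives 241 nM
compound 2 `COc1cc(-c2ccnc3cc(-c4cccc(C#N)c4)nn23)cc(OC)c1OC` gives > 10000 nM
compound 3 `COc1cc(-c2ccnc3cc(-c4ccc(N(C)C)cc4)nn23)cc(OC)c1OC` gives 378 nM

The entry for compound 2 is a limit of the assay and not a number. Among the measured compounds shown here, compound 3 matches compound 1, the only other true number, with a 1.6-fold higher number from compound 1 to compound 3 (0.20 log units; within the scatter) between them.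

Compound 4 `COc1cc(-c2ccnc3cc(-c4ccc(C(C)=O)cc4)nn23)cc(OC)c1OC` carries acetyl in place of dimethylamino on an aromatic carbon, para to a large group, as acetyl in place of dimethylamino on an aromatic carbon shows. Two kinds of measured step bear on this. Changing 3,4-dimethylphenyl to 4-(dimethylamino)phenyl gave only a 1.6-fold higher number from compound 1 to compound 3 (0.20 log units; within the scatter) and so no real shift. The 3-cyanophenyl group of compound 2 gave an at least 41-fold higher number from compound 1 to compound 2 (1.61 log units; beyond the scatter) and, on the way back, an at least 26-fold lower number from compound 2 to compound 3 (1.42 log units; beyond the scatter) in both cases a large step. Like that nitrile, acetyl has a multiple bond outside the aromatic rings, which the groups of compound 1 and compound 3 lack, but it sits at a different place on the phenyl ring. A moderate rise in the number is therefore expected, estimated as a 4.0-fold higher number from compound 3 to compound 4 (0.60 log units; beyond the scatter) in this assay for now. For compound 4 the expected value is 1500 nM within an estimated range of 300 nM to 8000 nM overall.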

Compound 4, half-maximal inhibitory concentration: 1810 nM
For compound 4 the middle estimate is 1.2-fold (0.08 log units) below the measured one; the range from low to high includes it.
By their numbers in this assay, from the lowest: compounds 1 and 3 (each within the scatter of the next); then compound 4. At a limit, above all of these: compound 2.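

In this assay, the place para to a large group on the phenyl ring responds to the group it carries: a 4.8-fold higher number from compound 3 to compound 4 (0.68 log units; beyond the scatter), although dimethylamino and acetyl have the same count of heavy atoms and of hydrogen-bond acceptors. The match between the 3,4-dimethylphenyl and 4-(dimethylamino)phenyl groups therefore does not extend to the 4-acetylphenyl group: a 7.5-fold higher number from compound 1 to compound 4 (0.88 log units; beyond the scatter). The entry for compound 2 is a limit and not a number, so only a bound can be read against the 3-cyanophenyl group: an at least 5.5-fold lower number from compound 2 to compound 4 (0.74 log units; beyond the scatter).

Acetyl and nitrile sit at different places on the phenyl ring, so the compounds shown cannot separate the choice of group from its place. A carboxylic acid or a simple amine para to a large group would show whether a multiple bond outside the aromatic rings goes with the higher numbers.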